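Replacing an imidazole with a furan on one aromatic carbon

This account rests on a few compounds, and the source may have more. Where it says the series, first, only, none or still open, it means among the compounds named here.

Of the compounds shown here, three sharing one core have been measured in a functional assay on DU-145 cells (Homo sapiens), read by sulforhodamine B assay, with a stated time of 5 days; a lower number here means a stronger inhibitor of growth, a higher number a weaker inhibitor of growth. Compound 1 `OC[C@H]1O[C@@H](n2cc(F)c3c(-c4ccccc4)ncnc32)[C@H](O)[C@@H]1O`, bearing phenyl, gives 580 nM. Compound 2 `OC[C@H]1O[C@@H](n2cc(F)c3c(-c4ccco4)ncnc32)[C@H](O)[C@@H]1O`, bearing furan-2-yl, gives 5 nM. Compound 3 `OC[C@H]1O[C@@H](n2cc(F)c3c(-c4c[nH]cn4)ncnc32)[C@H](O)[C@@H]1O`, bearing 1H-imidazol-4-yl, gives 890 nM. Compound 3 stands with compound 1 at the upper end of these numbers, since a 1.5-fold higher number from compound 1 to compound 3 (0.19 log units; within the scatter) lies within the scatter. Compound 2 stands far apart, with a 120-fold lower number from compound 1 to compound 2 (2.06 log units; beyond the scatter) and a 180-fold higher number from compound 2 to compound 3 (2.25 log units; beyond the scatter), both large.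

Compound 4 `OC[C@H]1O[C@@H](n2cc(F)c3c(-c4ccoc4)ncnc32)[C@H](O)[C@@H]1O` differs from compound 3 by one change, furan-3-yl in place of 1H-imidazol-4-yl on an aromatic carbon. Among the compounds with values here, no compound with this furan has been measured, so the closest guide is compound 2, and the step that bears most is a 180-fold higher number from compound 2 to compound 3 (2.25 log units; beyond the scatter), read in reverse. A large move to a lower number is therefore expected, perhaps not the full distance. The expected step is a 45-fold lower number from compound 3 to compound 4 (1.65 log units; beyond the scatter). Compound 4 is estimated at 20 nM, with an expected range of 4 nM to 150 nM.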

Compound 4, concentration for 50% growth inhibition: 5 nM
For compound 4 the middle estimate is 4.0-fold (0.60 log units) above the measured one, within the range that was stated.
By their numbers in this assay, from the lowest: compounds 2 and 4 (each within the scatter of the next); then compounds 1 and 3 (each within the scatter of the next).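

In this assay, moving the attachment point of the furan changes nothing that can be seen, with no change at the digits printed from compound 2 to compound 4 (within the scatter) as the step from furan-2-yl to furan-3-yl. Furan-3-yl also shows a large step against phenyl, a 120-fold lower number from compound 1 to compound 4 (2.06 log units; beyond the scatter), and against 1H-imidazol-4-yl, a 180-fold lower number from compound 3 to compound 4 (2.25 log units; beyond the scatter), so among the four compounds the low number belongs to both furans and not to one attachment alone. Nothing at hand accounts for the gap between the two furans and the other two rings.

From the compounds shown here alone, whether a thienyl ring in place of the furan would keep the low number remains open, as does the effect of a methyl group or an amine added to the furan. All of these readings also come from one cell line, so it is open whether the same order among these groups holds in other cells.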